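Inverting the ring configuration of compound 3

The source may report more compounds than this note shows. Statements on the series, on what has been measured and on what is new or still open speak of the compounds shown alone.

Compound 3 `N#Cc1cnc(NCc2cnccc2C(F)(F)F)cc1NC[C@H]1CC[C@@H](O)CC1` gives the lowest of the two numbers in an assay on isolated protein for inhibition of protein kinase C delta type (Homo sapiens), read by TR-FRET, with a stated time of 2 h (a higher number here means a weaker inhibitor, a lower number a stronger inhibitor), with 500 nM. Compound 1 `N#Cc1cnc(NCc2cnccc2C(F)(F)F)cc1N[C@H]1CC[C@H](O)CC1` gives 6500 nM, and a 13-fold lower number from compound 1 to compound 3 (1.11 log units; beyond the scatter). Compound 2 `CO[C@H]1CC[C@H](Nc2cc(NCc3cnccc3C(F)(F)F)ncc2C#N)CC1` reaches only the assay limit of > 10000 nM. From there, an at least 20-fold lower number from compound 2 to compound 3 (1.30 log units; beyond the scatter). Within the data shown here, compound 4 `N#Cc1cnc(NCc2cnccc2C(F)(F)F)cc1NC[C@H]1CC[C@H](O)CC1` keeps every atom and bond of compound 3; the only change is the two compounds have the same atoms and bonds and differ only in configuration as drawn: 2 of 2 stereo elements differ (all stereocentres are inverted: mirror images); a stereocentre at a saturated ring carbon is drawn s in compound 3 and r in compound 4; a stereocentre at a saturated ring carbon is drawn s in compound 3 and r in compound 4. Among the measured compounds shown here, none of the measured steps touches configuration: both steps into compound 3 altered the group on the nitrogen on an aromatic ring, so they offer no direct guide here. Compound 4 is therefore expected to stay near compound 3, with a modest step of a 3.0-fold higher number from compound 3 to compound 4 (0.48 log units; beyond the scatter) toward a higher number, estimated at 1500 nM within 300 nM to 8000 nM.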

Compound 4, half-maximal inhibitory concentration: 2000 nM
Estimate against measurement, compound 4: 1.3-fold (0.12 log units) below; the measured number falls inside the stated range.
By their numbers in this assay, from the lowest: compound 3; then compound 4; then compound 1. At a limit, above all of these: compound 2.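

In this assay, configuration alone moves the number, with a 4.0-fold higher number from compound 3 to compound 4 (0.60 log units; beyond the scatter), and the cause can lie in only one thing: the fact that compounds 3 and 4 differ only in the configuration as drawn. Among these compounds, the (4-hydroxycyclohexyl)methyl group still gives a lower number in the inverted form, with a 3.3-fold lower number from compound 1 to compound 4 (0.51 log units; beyond the scatter), though the gain is smaller than the one compound 3 shows. Only a floor can be read against an assay limit: an at least 5.0-fold lower number from compound 2 to compound 4 (0.69 log units; beyond the scatter).

Going by these compounds, it remains open whether an amine or a carboxylic acid in place of the hydroxyl would show the same dependence on configuration. On these data alone, whether a longer chain would lower the number further also remains open.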